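This account rests on a few compounds, and the source may have more. Where it says the series, first, only, none or still open, it means among the compounds named here.

Of the compounds shown here, three of one shared core have been measured in a functional assay (Homo sapiens) for antiproliferative activity, read by resazurin assay, with a stated time of 48 h, tested at 10 uM (on this read-out lower numbers stand for a weaker effect and higher numbers for a stronger effect at the one concentration tested), so far. Compound 1 `COc1cc(OC)c2c(=O)cc(-c3ccc(OCCF)cc3)oc2c1` gives "not active" (no number reported). Compound 2 `COc1cc(OC)c2c(=O)cc(-c3ccc(OCCCN)cc3)oc2c1` gives 39%, and compound 3 `COc1cc(OC)c2c(=O)cc(-c3ccc(OCC(O)CN(C)C)cc3)oc2c1` gives 60%. For the measured compounds named here, the only single-point step measured is a number 21 percentage points higher from compound 2 to compound 3 (beyond the scatter). Compound 3 therefore stands highest of the two numbers available, with compound 2 below it and compound 1 carrying no number.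

Compound 4 `COc1cc(OC)c2c(=O)cc(-c3ccc(-c4ccc(F)nc4)cc3)oc2c1` differs from compound 3 by 6-fluoropyridin-3-yl in place of 3-(dimethylamino)-2-hydroxypropoxy on an aromatic carbon. Going by the values given here, no measured step covers a change of this kind: the step from compound 2 to compound 3 only altered the chain on the oxygen, whereas here the whole chain is removed and an aromatic ring enters in its place. The nearest hint is compound 1, a shorter chain on that oxygen, which gave no measurable effect. A step of a number 40 percentage points lower from compound 3 to compound 4 (beyond the scatter) in this assay is therefore expected, downward and beyond the scatter, with wide uncertainty. Compound 4 is expected to give about 20%, within a range from 0% to 45%.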

Compound 4, a percentage reported as inhibition, at one concentration (the size of the read-out at that concentration, not a potency): 6%
Beside the measured number, compound 4's estimate is 14 percentage points above it; the range from low to high includes it.
By their numbers in this assay, from the lowest: compound 4; then compound 2; then compound 3.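

For the compounds shown here, compound 4 is the first here in which the chain on the oxygen is gone and an aromatic ring, 6-fluoropyridin-3-yl, sits directly on this aromatic carbon. In this assay the swap gives a number 54 percentage points lower from compound 3 to compound 4 (beyond the scatter) and a number 33 percentage points lower from compound 2 to compound 4 (beyond the scatter), so at this place, among these compounds, the two chains ending in an amine carry clearly higher numbers than the ring, although the ring has almost as many heavy atoms as the 3-(dimethylamino)-2-hydroxypropoxy chain it replaces. No measurement at hand gives a reason for this drop.

Going by these compounds, it remains open whether the loss comes from removing the oxygen link or from this particular ring. A plain phenyl ring, or a ring carrying a dimethylaminomethyl group, at the same place could help separate these two possibilities.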